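The compounds below may be only part of what the source reports. "The series", "measured", "known", "first", "only" and "open" are said of these compounds alone.

Compound 1 `CSCC[C@H](NC(=O)c1ccc(NCc2cncn2Cc2ccc(C#N)cc2)cc1-c1ccccc1)C(=O)O` — in a functional assay on NIH3T3 cells (Mus musculus) (on this read-out higher numbers stand for an effect only at larger amounts of compound and lower numbers for an effect already at smaller amounts), compound 1 gives > 10 uM.
Compound 2 `CSCC[C@H](NC(=O)c1ccc(NCc2cncn2Cc2cccc(Cl)c2)cc1-c1ccccc1)C(=O)O` — in this assay compound 2 gives > 10 uM.

Both figures are limits of this assay, not numbers. For compound 1 the value > 10 uM is such a limit. For compound 2 the value > 10 uM is likewise a limit. Among the measured compounds shown here, compound 2 therefore stands, on the numbers at hand, only at a limit, and the single other value shown is a limit as well, so no ranking between the two is readable. The step that the two limits leave unreadable from compound 1 to compound 2 is accordingly of unreadable size, a fact that rests on (the limit of > 10 uM in this assay, at which 2 of the 2 values shown sit).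

Compound 3 `CSCC[C@H](NC(=O)c1ccc(NCc2cncn2Cc2ccccc2Cl)cc1-c1ccccc1)C(=O)O` has not yet been measured in this assay. Its difference from compound 2 is 2-chlorophenyl in place of 3-chlorophenyl on a saturated chain carbon bound to an aromatic nitrogen. For the measured compounds named here, the only measured step, from compound 1 to compound 2, also concerns a chlorophenyl variant at this position and is unreadable, so it sets no size or direction. The step from compound 2 to compound 3 is expected to be a step that the limit leaves unreadable from compound 2 to compound 3, meaning no readable move. Compound 3 is therefore estimated at 20 uM, within 5 uM to 80 uM, most likely again a limit.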

Compound 3, concentration for half-maximal effect: > 10 uM
Compound 3 gave a limit, no number; the forecaster's own chance of this, stated with the estimate: 85%; the middle value does not contradict the limit.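

In this assay compound 3 gives > 10 uM, which is a limit and not a number. No step among compound 1, compound 2 and compound 3 can be read: the limit of > 10 uM in this assay, at which 3 of the 3 values shown sit.

The compounds shown leave open whether 4-cyanophenyl, 3-chlorophenyl and 2-chlorophenyl differ at all in this assay, and how large any such difference would be.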